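Propoxycarbonyl in place of methoxycarbonyl on compound 1

The source may report more compounds than this note shows. Statements on the series, on what has been measured and on what is new or still open speak of the compounds shown alone.

In an ADME assay on the whole organism (plasma) for metabolic stability, with Rattus norvegicus as the target (on this read-out higher numbers stand for a longer-lived compound and lower numbers for a shorter-lived compound), compound 1 `COC(=O)CCCC=C(c1cc(Cl)c(OC)c(C(=O)OC)c1)c1cc(Cl)c(OC)c(C(=O)OC)c1` gives 0.0967 h and so lies within the scatter of compound 3 `CCCOC(=O)CCCC=C(c1cc(Br)c(OC)c(C(=O)OC)c1)c1cc(Br)c(OC)c(C(=O)OC)c1` at 0.0567 h in this set. Compound 2 `COC(=O)CCCC=C(c1cc(C#N)c(OC)c(C(=O)OC)c1)c1cc(C#N)c(OC)c(C(=O)OC)c1` reads 0.207 h and stands above compound 1 beyond the scatter. Compound 4 `CCCOC(=O)CCCC=C(c1cc(Cl)c(OC)c(C(=O)OC)c1)c1cc(Cl)c(OC)c(C(=O)OC)c1` is compound 1 with methoxycarbonyl changed to propoxycarbonyl ethyl in place of hydrogen on a saturated chain carbon bound to an oxygen next to a carbonyl group. Within the data shown here, no measured pair isolates this change. Among the measured compounds shown here, compound 3 also carries propoxycarbonyl and its 0.0567 h is the only guide, so a small downward shift in this assay is expected. The estimated 1.4-fold lower number from compound 1 to compound 4 (0.14 log units; within the scatter) is expected to stay within the scatter. Compound 4 is estimated at 0.07 h (expected range 0.035 h to 0.14 h) in this read-out.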

Compound 4, half-life: 0.123 h
Estimate against measurement, compound 4: 1.8-fold (0.24 log units) below; measured number inside the range.
By their numbers in this assay, from the lowest: compounds 3, 1, 4 and 2 (each within the scatter of the next, the first and the last beyond it).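

In this assay, among these compounds, the pair gives the first direct reading of this change: a 1.3-fold higher number from compound 1 to compound 4 (0.10 log units; within the scatter), with ethyl in place of hydrogen on a saturated chain carbon bound to an oxygen next to a carbonyl group. On the core of compound 1, therefore, methoxycarbonyl to propoxycarbonyl leaves the two compounds within the scatter of each other. No evidence on the basis of this result is at hand.

As far as these compounds go, a butyl chain or a carboxylic acid in place of propoxycarbonyl remains open. So does the same change on the nitrile-bearing core of compound 2.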